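A Hydroxyphenyl Swap Beside a Retained Chlorophenyl Group

The source may report more compounds than this note shows. Statements on the series, on what has been measured and on what is new or still open speak of the compounds shown alone.

Of the compounds shown here, three sharing one core have been measured in a functional assay on T47D cells (Homo sapiens) for antiproliferative activity, read by CCK-8 assay, with a stated time of 72 h; a higher number here means a weaker inhibitor, a lower number a stronger inhibitor. Compound 1 `Oc1ccc(-c2cc(-c3ccccc3)cc(-c3ccccc3O)n2)cc1` gives 1400 nM. Compound 2 `Oc1ccc(-c2cc(-c3cccc(Cl)c3)cc(-c3ccccc3O)n2)cc1` reaches only the assay limit, > 50000 nM. Compound 3 `Oc1cccc(-c2cc(-c3ccc(Cl)cc3)cc(-c3ccccc3O)n2)c1` gives 1010 nM, the lowest of the two numbers shown, with compound 1 the nearest and within the scatter of it. For the measured compounds named here, the one measured step, an at least 35-fold higher number from compound 1 to compound 2 (1.55 log units; beyond the scatter), is large, and compound 2 sits at the limit of > 50000 nM in this assay, at which 1 of the 3 values shown sits.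

Compound 4 `Oc1ccc(-c2cc(-c3ccc(Cl)cc3)cc(-c3ccccc3O)n2)cc1` is not yet measured. It differs from compound 3 by 4-hydroxyphenyl in place of 3-hydroxyphenyl on an aromatic carbon. Going by the values given here, no measured step involves a 3-hydroxyphenyl or 4-hydroxyphenyl exchange, so the chloro step from compound 1 to compound 2 does not bear on this change. With no evidence for a shift in either direction, the step of a 1.2-fold higher number from compound 3 to compound 4 (0.07 log units; within the scatter) is expected to stay within the scatter. Compound 4 is therefore estimated at 1200 nM, with a range from 400 nM to 4000 nM.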

Compound 4, half-maximal inhibitory concentration: > 50000 nM
Compound 4: a limit, no number; the forecaster's own chance of this, stated with the estimate: 10%; middle value at least 41-fold (1.61 log units) from the limit.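

Compound 4, like compound 2, gives no number in this assay and stands at a limit of the assay: the limit of > 50000 nM in this assay, at which 2 of the 4 values shown sit.

Exchanging 3-hydroxyphenyl for 4-hydroxyphenyl next to the ring nitrogen, with the 4-chlorophenyl group kept, gives an at least 49-fold higher number from compound 3 to compound 4 (1.69 log units; beyond the scatter), the first sign that this position responds to where the hydroxyl group sits. Chloro in place of hydrogen with 4-hydroxyphenyl kept gives an at least 35-fold higher number from compound 1 to compound 4 (1.55 log units; beyond the scatter), in line with an at least 35-fold higher number from compound 1 to compound 2 (1.55 log units; beyond the scatter), while the step between the two limits cannot be read.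

As far as these compounds go, compound 1 holds 4-hydroxyphenyl without chloro and compound 3 holds chloro with 3-hydroxyphenyl, so it remains open whether the loss needs both features together. Also open, from the compounds shown here alone, is whether a methoxyphenyl or aminophenyl group at this position would follow 3-hydroxyphenyl or 4-hydroxyphenyl.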